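Series notes: removing one methoxy group from an aryl ring

The compounds below may be only part of what the source reports. "The series", "measured", "known", "first", "only" and "open" are said of these compounds alone.

Compound 1 `COc1ccc(-c2cc(/C=C/C(=O)c3ccc(N)cc3)[nH]n2)cc1` and compound 2 `COc1ccc(-c2cc(/C=C/C(=O)c3ccc(N)cc3)[nH]n2)cc1OC` share one core; compound 3 `COc1cc(C(=O)/C=C/c2cc(-c3cc(OC)c(OC)c(OC)c3)n[nH]2)cc(OC)c1OC` differs from compound 2 in more than one place, and the difference between the two cores is not broken down here. In a functional assay on SF-539 cells (Homo sapiens) for inhibition, read by sulforhodamine B assay, with a stated time of 48 h (on this read-out lower numbers stand for stronger inhibition of growth and higher numbers for weaker inhibition of growth), compound 1 gives 1470 nM, compound 2 gives 1730 nM and compound 3 gives 1290 nM. The change from compound 2 to compound 1 is hydrogen in place of methoxy on an aromatic carbon, and it made a 1.2-fold lower number from compound 2 to compound 1 (0.07 log units; within the scatter). Compound 4 `COc1ccc(-c2cc(/C=C/C(=O)c3cc(OC)c(OC)c(OC)c3)[nH]n2)cc1OC` arises from compound 3 by hydrogen in place of methoxy on an aromatic carbon; its place is additionally meta to a methoxy group (2 heavy atoms), so this is the same kind of change, not the same. Expected, because the earlier step of a 1.2-fold lower number from compound 2 to compound 1 (0.07 log units; within the scatter) stayed within the scatter, is a 1.0-fold lower number from compound 3 to compound 4 (0.01 log units; within the scatter). Compound 4 is estimated at 1250 nM, with a range from 700 nM to 2200 nM.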

Compound 4, concentration for 50% growth inhibition: 300 nM
Compound 4: middle estimate off by 4.2-fold (0.62 log units), on the high side; measured number outside the range, below it.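

In this assay, hydrogen in place of methoxy gives a 4.3-fold lower number from compound 3 to compound 4 (0.63 log units; beyond the scatter), so on this core the change has a size that stands out from the scatter. The same change does not carry over at the same size from one core to the other: the same change on two cores in this assay, a 1.2-fold lower number (0.07 log units; within the scatter) from compound 2 to compound 1 and a 4.3-fold lower number (0.63 log units; beyond the scatter) from compound 3 to compound 4, 3.7-fold (0.56 log units) apart, beyond the scatter of two such steps. Among the compounds shown here, these two pairs show only that the step depends on the core; the cores differ in more than one place, and nothing here tells which difference matters or why.

Open, on these data alone, is whether the larger step holds when the methoxy gives way to a hydroxyl group, a fluorine atom or an ethoxy group rather than hydrogen. Also open, as far as these compounds go, is how the same change behaves on further cores, such as one carrying a carboxylic acid in place of the amine of compound 1.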